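The source may hold more compounds than are shown below. What is called first, only, known or untested is meant among the compounds shown, and "the series" means these compounds.

In a functional assay on PC-3 cells (Homo sapiens) for inhibition, read by MTT assay, with a stated time of 48 h, tested at 10 uM (on this read-out higher numbers stand for more inhibition of growth at the one concentration tested and lower numbers for less inhibition of growth), compound 1 (`Cc1cc(=O)c2c(O)cc(O)c([C@H]3CCN(C)C[C@H]3OC(=O)c3ccco3)c2o1`) gives 23% as the higher of two numbers. Compound 2 (`Cc1cc(=O)c2c(O)c(CN3CCCC3)c(O)c([C@H]3CCN(C)C[C@H]3O)c2o1`) gives 10% as the lower one, a gap beyond the usual scatter. Compound 3 (`CCOC(=O)N1CCN(Cc2c(O)c([C@H]3CCN(C)C[C@H]3O)c3oc(C)cc(=O)c3c2O)CC1`) is still unmeasured and carries 4-(ethoxycarbonyl)piperazin-1-yl in place of pyrrolidin-1-yl on a saturated chain carbon bound to an aromatic carbon. For the measured compounds named here, no measured pair shows this change, so the expected step in this assay is none beyond the scatter (a number 4 percentage points higher from compound 2 to compound 3 (within the scatter)). For compound 3 the estimated value is 14% with an expected range (2% to 28%).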

Compound 3, percent growth inhibition at one concentration: 1%
For compound 3 the middle estimate is 13 percentage points above the measured one; measured number outside the range, below it.
By their numbers in this assay, from the lowest: compounds 3 and 2 (each within the scatter of the next); then compound 1.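

In this assay, for the compounds shown here, replacing pyrrolidin-1-yl with 4-(ethoxycarbonyl)piperazin-1-yl on the saturated chain carbon bound to an aromatic carbon gives a number 9 percentage points lower from compound 2 to compound 3 (within the scatter) and provides the first one-place comparison at this position. The position therefore accepts the six-membered ring with its ethyl carbamate without a step beyond the scatter. No measurement here explains this result.

On these data alone, whether morpholin-4-yl or an unsubstituted piperazin-1-yl at this place would read the same remains open. Also open, as far as these compounds go, is what a substituent at this place would do on the core of compound 1.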